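This account rests on a few compounds, and the source may have more. Where it says the series, first, only, none or still open, it means among the compounds named here.

Measured so far in an assay on a protein complex for inhibition of CDK8/Cyclin C (Homo sapiens), with a stated time of 1 h; a higher number here means a weaker inhibitor, a lower number a stronger inhibitor:
Compound 1 `CNC(=O)/C=C/c1ccncc1-c1ccc2[nH]ccc2c1` gives 51.9 nM.
Compound 2 `CNC(=O)CCc1ccncc1-c1ccc2ccccc2c1` gives 21.1 nM.
Compound 3 `COC1CN(C(=O)/C=C/c2ccncc2-c2ccc(F)cc2)C1` gives "not determined" (no result reported), that is, no result reported.

Compound 2 has the lowest of the two numbers; compound 1 is the nearest, with a higher number beyond the scatter. Compound 4 `CCOC(=O)/C=C/c1ccncc1-c1ccc2ccccc2c1` differs from compound 2 in one place: 2-(ethoxycarbonyl)ethenyl in place of 2-(methylcarbamoyl)ethyl on an aromatic carbon. For the measured compounds named here, no step between measured compounds is available, so the size of this step in this assay is judged from the change alone: the single hydrogen-bond donor of the leaving group is lost, and a moderate rise in the number, beyond the scatter, is expected. Compound 4 is expected to give about 60 nM, within 20 nM to 200 nM, which would mean an expected step of a 2.8-fold higher number from compound 2 to compound 4 (0.45 log units; beyond the scatter).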

Compound 4, half-maximal inhibitory concentration: 53.3 nM
Compound 4: the middle estimate sits 1.1-fold (0.05 log units) above what was measured; the measured number falls inside the stated range.
By their numbers in this assay, from the lowest: compound 2; then compounds 1 and 4 (each within the scatter of the next).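

In this assay, the position opposite the ring nitrogen accepts 2-(ethoxycarbonyl)ethenyl in place of 2-(methylcarbamoyl)ethyl, with a 2.5-fold higher number from compound 2 to compound 4 (0.40 log units; beyond the scatter) as a modest cost. This first single-place step shows that a chain with no hydrogen-bond donor still keeps the number in the same range as compound 2, although amide, ester and double bond all change at once. No evidence on the cause of the step is available.

Going by these compounds, how much of the step belongs to the extra double bond and how much to the ester remains open. A carboxylic acid or an amine on this chain also remains untested among the compounds shown.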